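The source may report more compounds than this note shows. Statements on the series, on what has been measured and on what is new or still open speak of the compounds shown alone.

Values in a functional assay on MGC-803 cells (Homo sapiens) for cytotoxicity, read by MTT assay, with a stated time of 38 h; a lower number here means a stronger inhibitor, a higher number a weaker inhibitor:
- Compound 1 `COc1cc(OC)c2c(=O)c(OCCCCN3CCCC3)c(-c3cc(OC)c(OC)c(OC)c3)oc2c1`: 18600 nM
- Compound 2 `COc1cc(OC)c2c(=O)c(OCCCN3CCCC3)c(-c3cc(OC)c(OC)c(OC)c3)oc2c1`: 32100 nM
- Compound 3 `COc1cc(OC)c2c(=O)c(OCCCCN3CCN(C)CC3)c(-c3cc(OC)c(OC)c(OC)c3)oc2c1`: 12200 nM

Compound 3 and compound 1 cannot be told apart, as the step is a 1.5-fold lower number from compound 1 to compound 3 (0.18 log units; within the scatter). Compound 3 does separate from compound 2, with a 2.6-fold lower number from compound 2 to compound 3 (0.42 log units; beyond the scatter).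

The next compound is compound 4 `COc1cc(OC)c2c(=O)c(OCC(=O)N/N=C/c3ccco3)c(-c3cc(OC)c(OC)c(OC)c3)oc2c1`, and the change from compound 3 is a group of 10 heavy atoms (6 carbon, 2 nitrogen, 2 oxygen; one five-membered aromatic ring with 1 hetero atom) in place of a group of 10 heavy atoms (8 carbon, 2 nitrogen; one six-membered non-aromatic ring with 2 hetero atoms), on a saturated chain carbon bound to an oxygen on an aromatic ring. In words, a group with one five-membered aromatic ring with 1 hetero atom replaces a group with one six-membered non-aromatic ring with 2 hetero atoms, on a saturated chain carbon bound to an oxygen on an aromatic ring.

The measured steps offer only limited guidance. Two of them stay within the scatter, a 1.7-fold higher number from compound 1 to compound 2 (0.24 log units; within the scatter) and the step to compound 3 already given. Among the measured compounds shown here, only the step from compound 2 goes beyond it, and modestly. For the measured compounds named here, all three compounds carry pyrrolidin-1-yl or 4-methylpiperazin-1-yl, so no measured step resembles this replacement, and the data cannot exclude a larger move in either direction.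

In this assay, the expected change is small and leans towards a higher number, not clearly beyond the scatter: a 1.6-fold higher number from compound 3 to compound 4 (0.21 log units; within the scatter). Compound 4 is estimated at 20000 nM, with an expected range from 6000 nM to 60000 nM.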

Compound 4, half-maximal inhibitory concentration: 6050 nM
Compound 4: the middle estimate sits 3.3-fold (0.52 log units) above what was measured; measured number inside the range.
By their numbers in this assay, from the lowest: compounds 4, 3, 1 and 2 (each within the scatter of the next, the first and the last beyond it).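

Among the compounds shown here, at the saturated chain carbon bound to an oxygen on an aromatic ring, the earlier compounds carried only pyrrolidin-1-yl or 4-methylpiperazin-1-yl groups, and compound 4 shows that a group with a five-membered aromatic ring with 1 hetero atom cannot be told apart in this assay from the group of compound 3 (a 2.0-fold lower number from compound 3 to compound 4 (0.30 log units; within the scatter)). The same group does separate from both pyrrolidin-1-yl compounds (a 3.1-fold lower number from compound 1 to compound 4 (0.49 log units; beyond the scatter) and a 5.3-fold lower number from compound 2 to compound 4 (0.72 log units; beyond the scatter)), whereas the group of compound 3 separates only from compound 2. Nothing at hand explains why the numbers fall this way.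

The compounds shown leave open whether the result follows the five-membered aromatic ring or the two double bonds outside aromatic rings that come with it, and a phenyl or thiophene ring in place of that ring would begin to tell these apart. They also leave open how a simple carboxylic acid or a morpholine group would read at the same chain carbon.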